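Working notes on the series: from compound 2 to compound 3

The source may report more compounds than this note shows. Statements on the series, on what has been measured and on what is new or still open speak of the compounds shown alone.

Measured so far:
compound 1 `Oc1ccc(-c2cc(-c3ccccc3F)cc(-c3ccccc3O)n2)cc1`; in a functional assay on HCT-15 cells (Homo sapiens) for inhibition (a higher number here means a weaker inhibitor, a lower number a stronger inhibitor), compound 1 gives > 50000 nM, which is a limit of the assay and not a number.
compound 2 `Oc1ccc(-c2cc(-c3ccccc3F)cc(-c3cccc(O)c3)n2)cc1`; in this assay compound 2 gives 5630 nM.

Among the measured compounds shown here, compound 2 holds the only number so far in this assay; the remaining value is a limit (the limit of > 50000 nM in this assay, at which 1 of the 2 values shown sits). For the measured compounds named here, the single measured step, an at least 8.8-fold lower number from compound 1 to compound 2 (0.94 log units; beyond the scatter), exchanges 2-hydroxyphenyl for 3-hydroxyphenyl, a different part of the shared core from the one varied next.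

Compound 3 `Oc1ccc(-c2cc(-c3ccc(C(F)(F)F)cc3)cc(-c3cccc(O)c3)n2)cc1` is not yet measured. It differs from compound 2 by 4-(trifluoromethyl)phenyl in place of 2-fluorophenyl on an aromatic carbon. Going by the values given here, no measured step touches this part of the shared core, so an at least 8.8-fold lower number from compound 1 to compound 2 (0.94 log units; beyond the scatter) gives no guide to the size or direction of the change. With nothing to point either way, the step of a 1.1-fold lower number from compound 2 to compound 3 (0.05 log units; within the scatter) is expected to fall within the scatter, though the range has to stay wide. The estimate for compound 3 in this assay is 5000 nM, with a range from 1500 nM to 20000 nM.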

Compound 3, half-maximal inhibitory concentration: 6440 nM
Compound 3: the middle estimate sits 1.3-fold (0.11 log units) below what was measured, and the stated range covers the measured number.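

The position opposite the ring nitrogen now has a measured step in this assay: a 1.1-fold higher number from compound 2 to compound 3 (0.06 log units; within the scatter), with 4-(trifluoromethyl)phenyl in place of 2-fluorophenyl. Among the compounds shown here, this position therefore accepts a group of 10 heavy atoms in place of one of 7 with no readable shift in the number, in contrast to the only earlier step, an at least 8.8-fold lower number from compound 1 to compound 2 (0.94 log units; beyond the scatter), which lies beyond the scatter and belongs to the hydroxyphenyl part of the shared core. No measurement shown offers a reason for this result.

Compound 2 and compound 3 differ both in the fluorine-bearing group and in where it sits on the phenyl ring, so these two changes cannot be read apart, and two fluorinated phenyl groups say little about the range of groups this position accepts. Going by these compounds, whether the number in this assay would hold with an amine, a carboxylic acid or a longer alkyl chain on this position, rather than a fluorinated phenyl group, remains open.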